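Swapping the amine ring at the sulfonyl-flanked position

The source may hold more compounds than are shown below. What is called first, only, known or untested is meant among the compounds shown, and "the series" means these compounds.

Compound 1 `CC1CCN(c2c(S(=O)(=O)c3ccccc3)cnc3ccccc23)CC1`: 89.2%
Compound 2 `CCN1CCN(c2c(S(=O)(=O)c3ccccc3)cnc3ccccc23)CC1`: 1.7%
Compound 3 `Cc1ccc(S(=O)(=O)c2cnc3c(F)cccc3c2N2CCC(C)CC2)cc1F`: 93%

In an assay on isolated protein for displacement of a labelled ligand from metabotropic glutamate receptor 5 (Homo sapiens), with a stated time of 60 min, tested at 1 uM (on this read-out lower numbers stand for less inhibition and higher numbers for more inhibition at the one concentration tested (going by the name of the read-out)), compound 2 stands lowest of the three, with compound 1 its nearest neighbour and compound 3 its furthest; compound 1 and compound 3 both read high, and their two values sit close together. For the measured compounds named here, the only measured step that touches the amine ring on the shared core is a number 87.5 percentage points lower from compound 1 to compound 2 (beyond the scatter), which shows the ethylpiperazine ring wiping out nearly all of the inhibition seen with the methylpiperidine ring.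

Compound 4 `O=S(=O)(c1ccccc1)c1cnc2ccccc2c1N1CCCC1` differs from compound 2 in that ring: pyrrolidin-1-yl in place of 4-ethylpiperazin-1-yl on an aromatic carbon. The change removes the second ring nitrogen that came in with the ethylpiperazine. Going by the values given here, since the only relevant step, a number 87.5 percentage points lower from compound 1 to compound 2 (beyond the scatter), was large and ran downward on introducing that ring, its removal in compound 4 is expected to run upward, although a five-membered ring has not been measured here, so the size is uncertain. For compound 4 the estimated reading in this assay is 60%, within 20% to 95%, an expected step of a number 58.3 percentage points higher from compound 2 to compound 4 (beyond the scatter).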

Compound 4, a percentage reported as inhibition, at one concentration (the size of the read-out at that concentration, not a potency): 7.1%
Compound 4: the middle estimate sits 52.9 percentage points above what was measured, outside the stated range (below it).
By their numbers in this assay, from the lowest: compounds 2 and 4 (each within the scatter of the next); then compounds 1 and 3 (each within the scatter of the next).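

In this assay, replacing 4-ethylpiperazin-1-yl with pyrrolidin-1-yl gives a number 5.4 percentage points higher from compound 2 to compound 4 (within the scatter), so this change recovers none of the inhibition lost in compound 2, even though the entering ring carries only one nitrogen. The step of a number 82.1 percentage points lower from compound 1 to compound 4 (beyond the scatter) shows that a second amine ring at this position, opposite the ring nitrogen, also reads far lower than 4-methylpiperidin-1-yl, so the high reading of compound 1 does not carry over to either replacement. No measurement on hand explains why these rings behave alike.

The compounds shown leave open whether the high reading depends on the six-membered piperidine ring or on its methyl group. A plain piperidin-1-yl ring, a 4-ethylpiperidin-1-yl ring or a morpholin-4-yl ring on the core of compound 1 would separate these possibilities.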